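The source may hold more compounds than are shown below. What is called first, only, known or untested is meant among the compounds shown, and "the series" means these compounds.

Measured so far:
- compound 1 `CNC(=O)c1ncc([N+](=O)[O-])[nH]1`: > 100000 nM
- compound 2 `CN(C)C(=O)c1nc([N+](=O)[O-])cn1Cc1ccc(OC(F)(F)F)cc1`: > 100000 nM

In a toxicity assay on HepG2 cells (Homo sapiens) for inhibition, read by resazurin assay, with a stated time of 24 h (a higher number here means that more compound is tolerated, a lower number that less compound is tolerated), compound 1 gives > 100000 nM, which is a limit and not a number. In this assay compound 2 gives > 100000 nM, again only a limit. Neither compound has a measured half-maximal cytotoxic concentration, so the position of compound 2 is known only as the limit of > 100000 nM in this assay, at which 2 of the 2 values shown sit.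

The next compound is compound 3 `NNC(=O)c1nc([N+](=O)[O-])cn1Cc1ccc(OC(F)(F)F)cc1`, which has aminoamino in place of dimethylamino on a carbonyl carbon. The rest of the structure matches compound 2. Within the data shown here, no measured step shows what such a change does, so the expectation rests on (the limit of > 100000 nM in this assay, at which 2 of the 2 values shown sit).

No step beyond the usual scatter is the most likely outcome, with a modest move toward less compound tolerated as the main alternative. The expected step is an at least 1.1-fold lower number from compound 2 to compound 3 (0.04 log units; that floor lies within the scatter). A report of a limit again would fit this expectation. The estimated value for compound 3 is 90000 nM, with an expected range of 35000 nM to 200000 nM.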

Compound 3, half-maximal cytotoxic concentration: > 100000 nM
Compound 3 gave a limit, no number; the forecaster's own chance of this, stated with the estimate: 65%; middle value at least 1.1-fold (0.04 log units) away from the limit.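

In this assay compound 3 gives > 100000 nM, a limit and not a number. Compound 2 also stands only as a limit, so no step can be read for aminoamino in place of dimethylamino on a carbonyl carbon. Still open is what structural change, if any, would bring a half-maximal cytotoxic concentration within measurable range: the limit of > 100000 nM in this assay, at which 3 of the 3 values shown sit.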